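This account rests on a few compounds, and the source may have more. Where it says the series, first, only, none or still open, it means among the compounds named here.

In an assay on isolated protein for displacement of a labelled ligand from D(1B) dopamine receptor (Homo sapiens) (a higher number here means a weaker inhibitor, a lower number a stronger inhibitor), compound 3 `C=CCN1CCc2cc(O)c(O)cc2C(c2ccccc2Br)C1` gives 442 nM, the second highest of three numbers. Within the data shown here, its nearest neighbour is compound 2 `C=CCN1CCc2cc(OC)c(O)cc2C(c2ccccc2Br)C1` with 501 nM; the only measured step, a 1.1-fold lower number from compound 2 to compound 3 (0.05 log units; within the scatter), lies within the scatter and concerns a different change. Compound 1 `COc1cc2c(cc1O)C(c1c(Cl)cccc1Cl)CNCC2` gives 25.4 nM, a far lower number. Compound 4 `Oc1cc2c(cc1O)C(c1ccccc1Br)CNCC2` differs from compound 3 in one place: hydrogen in place of allyl on an amine nitrogen in a ring. Among the measured compounds shown here, no measured step covers this exact change. Compound 1 also carries hydrogen on its amine nitrogen in a ring, yet it differs from compound 3 in other places too, so its low number is only a loose hint. A modest move towards a lower number is expected, a 2.9-fold lower number from compound 3 to compound 4 (0.47 log units; beyond the scatter). Compound 4 is estimated at 150 nM, with a range from 45 nM to 500 nM.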

Compound 4, inhibition constant: 67 nM
The estimate for compound 4 lay 2.2-fold (0.35 log units) above the measured number; the range from low to high includes it.
By their numbers in this assay, from the lowest: compound 1; then compound 4; then compounds 3 and 2 (each within the scatter of the next).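

Replacing allyl with hydrogen on the amine nitrogen in the ring gives a 6.6-fold lower number from compound 3 to compound 4 (0.82 log units; beyond the scatter) in this assay, a shift beyond the scatter. Among these compounds, this shows that the group on this nitrogen matters here, whereas the one earlier step, a 1.1-fold lower number from compound 2 to compound 3 (0.05 log units; within the scatter), a change on an oxygen, stayed within the scatter. Among the compounds shown, this nitrogen carries only hydrogen or allyl, so it remains open where a methyl group, a saturated propyl chain or a benzyl group would fall. Nothing available explains the size of this step.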